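Swapping 3-nitrophenyl for pyridin-4-yl on a carbonyl carbon

The source may hold more compounds than are shown below. What is called first, only, known or untested is meant among the compounds shown, and "the series" means these compounds.

In a functional assay on KB cells (Homo sapiens) for antiproliferative activity, read by sulforhodamine B assay, with a stated time of 3 days (on this read-out higher numbers stand for weaker inhibition of growth and lower numbers for stronger inhibition of growth), compound 3 (`O=C(Nc1cccc(Nc2ncc(F)c(Nc3ccc(F)cc3)n2)c1)c1cccc([N+](=O)[O-])c1`) gives 15100 nM and compound 1 (`O=C(Nc1ccccn1)c1cccc(Nc2ncc(F)c(Nc3ccc(F)cc3)n2)c1`) gives 20000 nM with the gap lying within the usual scatter. For compound 2 (`O=C(Nc1nccs1)c1cccc(Nc2ncc(F)c(Nc3ccc(F)cc3)n2)c1`) the reading > 10000 nM is a limit and not a number. Compound 4 (`O=C(Nc1cccc(Nc2ncc(F)c(Nc3ccc(F)cc3)n2)c1)c1ccncc1`) carries pyridin-4-yl in place of the 3-nitrophenyl of compound 3 on a carbonyl carbon (pyridin-4-yl in place of 3-nitrophenyl on a carbonyl carbon). Among the measured compounds shown here, the one measured step is a step that the limit leaves unreadable from compound 1 to compound 2 and it lies on an amide-type nitrogen, so it offers no size to carry over. Starting from compound 3 at 15100 nM no shift beyond the scatter is expected in either direction. The expected result is a 1.2-fold lower number from compound 3 to compound 4 (0.07 log units; within the scatter) and no more. For compound 4 the estimate is 13000 nM with an expected range from 5000 nM to 30000 nM as its span.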

Compound 4, concentration for 50% growth inhibition: 5280 nM
Estimate against measurement, compound 4: 2.5-fold (0.39 log units) above; the range from low to high includes it.
By their numbers in this assay, from the lowest: compound 4; then compounds 3 and 1 (each within the scatter of the next).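

In this assay, the group on this carbonyl carbon gives the first readable size: a 2.9-fold lower number from compound 3 to compound 4 (0.46 log units; beyond the scatter). Moving to the amide of compound 4 from that of compound 1, ((pyridin-4-yl)carbonyl)amino in place of (pyridin-2-yl)carbamoyl gives a 3.8-fold lower number from compound 1 to compound 4 (0.58 log units; beyond the scatter). Compound 2 reads > 10000 nM, a limit and not a number, so its step offers only a floor, an at least 1.8-fold lower number from compound 2 to compound 4 (0.27 log units; that floor lies within the scatter): the limit of > 10000 nM in this assay, at which 1 of the 4 values shown sits.

Still open, on these data alone, is whether the gain belongs to the pyridine ring nitrogen or simply to the loss of the nitro group. Plain phenyl or pyridin-3-yl on this carbonyl carbon would separate the two.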